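Benzyl Ester on a Methoxy Core: Expected Cytotoxicity

This account rests on a few compounds, and the source may have more. Where it says the series, first, only, none or still open, it means among the compounds named here.

The series rests on compound 1 `C=C1C(=O)[C@]23C[C@@]1(OCC)CC[C@H]2[C@@]12C=CC(=O)[C@](C)(C(=O)O1)[C@H]2[C@@H]3C(=O)OC`, which in a functional assay on HepG2 cells (Homo sapiens) for cytotoxicity, read by MTT assay (on this read-out lower numbers stand for stronger inhibition and higher numbers for weaker inhibition), gives 120000 nM. Two changes to it have been measured. Compound 2 `C=C1C(=O)[C@]23C[C@@]1(OCC)CC[C@H]2[C@@]12C=CC(=O)[C@](C)(C(=O)O1)[C@H]2[C@@H]3C(=O)OCc1ccccc1` carries phenyl in place of hydrogen on a saturated chain carbon bound to an oxygen next to a carbonyl group and in this assay compound 2 gives 29600 nM, a step of a 4.1-fold lower number from compound 1 to compound 2 (0.61 log units; beyond the scatter). Compound 3 `C=C1C(=O)[C@]23C[C@@]1(OC)CC[C@H]2[C@@]12C=CC(=O)[C@](C)(C(=O)O1)[C@H]2[C@@H]3C(=O)OC` differs from compound 1 by hydrogen in place of methyl on a saturated chain carbon bound to an oxygen on a saturated carbon; in this assay compound 3 gives 43500 nM, a step of a 2.8-fold lower number from compound 1 to compound 3 (0.44 log units; beyond the scatter). The gap between compound 2 and compound 3 lies within the scatter, so no order between those two is claimed.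

Compound 4 `C=C1C(=O)[C@]23C[C@@]1(OC)CC[C@H]2[C@@]12C=CC(=O)[C@](C)(C(=O)O1)[C@H]2[C@@H]3C(=O)OCc1ccccc1` has not been measured. It differs from compound 3 by phenyl in place of hydrogen on a saturated chain carbon bound to an oxygen next to a carbonyl group. This is the same change as that from compound 1 to compound 2, made at the same place on the core of compound 3, whose difference from the core of compound 1 is the one just told. For the measured compounds named here, with only one measured instance of the change, the expectation rests on that single step.

The step from compound 3 to compound 4 in this assay is estimated at a 3.6-fold lower number from compound 3 to compound 4 (0.56 log units; beyond the scatter), beside the measured 4.1-fold lower number from compound 1 to compound 2 (0.61 log units; beyond the scatter), because compound 3 starts from 43500 nM. Compound 4 is therefore expected to give 12000 nM in this assay, with a range of 5000 nM to 30000 nM. Whether the two changes add up as this assumes cannot be checked from the compounds at hand.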

Compound 4, half-maximal inhibitory concentration: 35000 nM
Beside the measured number, compound 4's estimate is 2.9-fold (0.46 log units) below it; the measured number lies above the stated range.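

On the core of compound 3, the change from methoxycarbonyl to benzyloxycarbonyl gives a 1.2-fold lower number from compound 3 to compound 4 (0.09 log units; within the scatter) in this assay, so the step seen on the core of compound 1 does not carry over at the same size: the same change on two cores in this assay, a 4.1-fold lower number (0.61 log units; beyond the scatter) from compound 1 to compound 2 and a 1.2-fold lower number (0.09 log units; within the scatter) from compound 3 to compound 4, 3.3-fold (0.51 log units) apart, beyond the scatter of two such steps

The other change, hydrogen in place of methyl on a saturated chain carbon bound to an oxygen on a saturated carbon, likewise loses its earlier size on the benzyl ester, with a 1.2-fold higher number from compound 2 to compound 4 (0.07 log units; within the scatter): the same change on two cores in this assay, a 2.8-fold lower number (0.44 log units; beyond the scatter) from compound 1 to compound 3 and a 1.2-fold higher number (0.07 log units; within the scatter) from compound 2 to compound 4, 3.3-fold (0.51 log units) apart, beyond the scatter of two such steps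

Within these four compounds the two changes therefore do not add up, as each one moves the number beyond the scatter only when made on compound 1, but this square alone does not show why they fail to add, nor how either change would behave on any other core.

The compounds shown leave open whether the same holds for other groups at the ester, such as an ethyl ester, a phenethyl ester or the free carboxylic acid. They also leave open whether a longer chain than ethoxy, such as propoxy, would continue the trend from compound 3 to compound 1 and whether any of this extends beyond this assay.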